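A few compounds are considered here, and "the series" means these few. Any claim that something is new, unique, unknown or untested is made for them only; others in the source may bear on it.

- Compound 1 `O=S(=O)(Cc1ccccc1)N1CCC2(CC1)OOC1(CCCC1)OO2`: > 100 ug/mL, a limit
- Compound 2 `Cc1ccc(S(=O)(=O)N2CCC3(CC2)OOC2(CCCCCC2)OO3)cc1`: > 100 ug/mL, a limit
- Compound 3 `CCCC1(C)OOC2(CCN(S(=O)(=O)CCC)CC2)OO1`: > 100 ug/mL, a limit

The test here is a functional assay on Huh-7 cells (Homo sapiens) for cytotoxicity, read by MTT assay, with a stated time of 72 h; a higher number here means that more compound is tolerated, a lower number that less compound is tolerated. Compound 3 gives > 100 ug/mL, which is a limit and not a number. It has company, as the three compounds share one reading: the limit of > 100 ug/mL in this assay, at which 3 of the 3 values shown sit.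

Compound 4 `CCCS(=O)(=O)N1CCC2(CC1)OOC(C)(c1ccc(Cl)cc1)OO2` is still unmeasured. It differs from compound 3 by 4-chlorophenyl in place of propyl on a saturated ring carbon.

That change brings in an aromatic ring. Compound 2 already carries an aromatic ring elsewhere in its structure and still gives > 100 ug/mL, again a limit. No step beyond the usual scatter is therefore expected in this assay, although any change that did appear would more likely be towards less compound being tolerated. The expected step is a number no higher from compound 3 to compound 4 (the limit leaves the size open). Compound 4 is estimated at 100 ug/mL. Its expected range runs from 40 ug/mL to 200 ug/mL.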

Compound 4, half-maximal cytotoxic concentration: > 100 ug/mL
Compound 4 was reported as a limit; the forecaster's own chance of this, stated with the estimate: 65%; the middle value sits exactly at the limit.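

No step can be read from compound 3 to compound 4, since both values are limits and all the compounds shown share one reading: the limit of > 100 ug/mL in this assay, at which 4 of the 4 values shown sit.

The compounds shown leave open at what concentration any of them harms these cells, and whether 4-chlorophenyl in place of propyl shifts that concentration.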